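Removing a methoxy group on a trimethoxyphenyl ketone

A few compounds are considered here, and "the series" means these few. Any claim that something is new, unique, unknown or untested is made for them only; others in the source may bear on it.

Compound 1, `COc1ccc(-c2cc(/C=C/C(=O)c3ccc(N)cc3)[nH]n2)cc1`, gives 87% in a functional assay on Malme-3M cells (Homo sapiens) for cytotoxicity, read by sulforhodamine B assay, with a stated time of 48 h, tested at 1 uM; a higher number here means a weaker effect of the compound at the concentration tested, a lower number a stronger effect. Compound 2, `COc1ccc(-c2cc(/C=C/C(=O)c3ccc(N)cc3)[nH]n2)cc1OC`, gives 114% in this assay. Compound 3, `COc1cc(C(=O)/C=C/c2cc(-c3cc(OC)c(OC)c(OC)c3)n[nH]2)cc(OC)c1OC`, gives 89% in this assay.

Between compound 2 and compound 1 the change is hydrogen in place of methoxy on an aromatic carbon, and it produced a number 27 percentage points lower from compound 2 to compound 1 (beyond the scatter). The difference between the core of compound 3 and that of compound 2 is not broken down here. Compound 3 and compound 1 sit within the scatter of each other, while compound 3 stands beyond the scatter from compound 2.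

Compound 4, `COc1ccc(-c2cc(/C=C/C(=O)c3cc(OC)c(OC)c(OC)c3)[nH]n2)cc1OC`, is not yet measured. It differs from compound 3 by hydrogen in place of methoxy on an aromatic carbon. This is the same kind of change as that from compound 2 to compound 1, but the surroundings differ: here the site is also meta to a methoxy group, which is not the case in the earlier pair.

Among the compounds with values here, because the earlier step gave a number 27 percentage points lower from compound 2 to compound 1 (beyond the scatter), a drop of comparable direction is expected for compound 4, though the changed surroundings and the single precedent make its size uncertain. The step from compound 3 to compound 4 is estimated as a number 19 percentage points lower from compound 3 to compound 4 (beyond the scatter). Compound 4 is therefore expected to give about 70%, between 50% and 95%.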

Compound 4, a percentage reported as activity, at one concentration (the size of the read-out at that concentration, not a potency): 93%
The estimate for compound 4 lay 23 percentage points below the measured number, within the range that was stated.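

In this assay, taking out the methoxy group gave a number 4 percentage points higher from compound 3 to compound 4 (within the scatter), so the result seen on the other core did not repeat here. The same replacement therefore does not carry over unchanged between these two cores: the same change on two cores in this assay, a number 27 percentage points lower (beyond the scatter) from compound 2 to compound 1 and a number 4 percentage points higher (within the scatter) from compound 3 to compound 4, 31 percentage points apart, beyond the scatter of two such steps. Within the data shown here, with only two pairs, this shows that the outcome of the change differs with the core, but it does not show which feature of the cores accounts for the difference or how the change would read on a third core.

Every compound shown keeps at least one methoxy group on the aromatic ring where the change takes place, so it remains open how a hydroxyl group, a chlorine atom or a longer alkoxy chain would read at that site. Also open, going by these compounds, is how a carboxylic acid in place of the amine shared by compound 1 and compound 2 would read in this assay.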